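This account rests on a few compounds, and the source may have more. Where it says the series, first, only, none or still open, it means among the compounds named here.

Compound 1 `CCCCCC(=O)Nc1ncc(C(Oc2ccc3cc(Br)ccc3c2)c2ccc(Cl)cc2)s1`: > 50000 nM
Compound 2 `O=S(=O)(Nc1ncc(C(Oc2ccc3cc(Br)ccc3c2)c2ccc(Cl)cc2)s1)c1cccs1`: "not toxic" (no number reported)

In an ADME assay on HepG2 2.2.15 cells (Homo sapiens) for cytotoxicity (on this read-out higher numbers stand for lower toxicity in this test and lower numbers for higher toxicity in this test), compound 1 is reported only as a limit of the assay, not as a number. Within the data shown here, compound 2 carries no number at all in this assay, being described simply as not toxic, so no single figure places it on this scale; the one further value shown is the limit of > 50000 nM in this assay, at which 1 of the 2 values shown sits. Compound 3 `O=S(=O)(Nc1ncc(C(Oc2ccc3cc(Br)ccc3c2)c2ccc(Cl)cc2)s1)c1cccc2nsnc12` differs from compound 2 in one place: a group of 9 heavy atoms (6 carbon, 2 nitrogen, 1 sulfur; one five-membered aromatic ring with 3 hetero atoms, one six-membered aromatic ring of carbon only) in place of a group of 5 heavy atoms (4 carbon, 1 sulfur; one five-membered aromatic ring with 1 hetero atom), on a sulfonyl sulfur. Since no measured step between any pair of compounds is shown, no change of known size can be carried over to this exchange; on the two results at hand one expects no shift beyond the usual scatter in this assay, and most likely once more a limit rather than a number. In this assay compound 3 is therefore estimated at 50000 nM, with a range from 20000 nM to 100000 nM.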

Compound 3, half-maximal cytotoxic concentration: "not toxic" (no number reported)
No number was reported for compound 3, and the estimate cannot be compared.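

Compound 2 and compound 3 are both described in this assay only as not toxic, without a number, so no step can be read between them. The compounds shown leave open whether exchanging thiophen-2-yl for the group of 9 heavy atoms on the sulfonyl sulfur shifts the half-maximal cytotoxic concentration at all.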